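Compound 2 to compound 3: fluoro gives way to cyclopentylcarbamoyl

The compounds below may be only part of what the source reports. "The series", "measured", "known", "first", "only" and "open" are said of these compounds alone.

In a functional assay on MCF7 cells (Homo sapiens) for antiproliferative activity, read by CCK-8 assay, with a stated time of 72 h (on this read-out higher numbers stand for weaker inhibition of growth and lower numbers for stronger inhibition of growth), compound 1 (`CC[C@@H]1C(=O)N(C)c2cnc(Nc3ccc(S(=O)(=O)NCCCO)cc3)nc2N1C1CCCC1`) gives 363 nM while compound 2 (`CCC1C(=O)N(C)c2cnc(-n3ccc4cc(F)ccc43)nc2N1c1ccn(C)n1`) gives 24700 nM as the higher of the two numbers, a gap beyond the scatter. Compound 3 (`CCC1C(=O)N(C)c2cnc(-n3ccc4cc(C(=O)NC5CCCC5)ccc43)nc2N1c1ccn(C)n1`) carries cyclopentylcarbamoyl in place of fluoro on an aromatic carbon. Within the data shown here, no measured step covers this change, so in this assay only a moderate step toward stronger inhibition of growth is expected, and that expectation is uncertain. The expected change is a 3.1-fold lower number from compound 2 to compound 3 (0.49 log units; beyond the scatter) on this estimate. Compound 3 is estimated at 8000 nM within a range from 1500 nM to 30000 nM on this read-out.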

Compound 3, concentration for 50% growth inhibition: "not active" (no number reported)
For compound 3 the study gives words and no number, and the estimate cannot be compared.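

Among these compounds, compound 3 is reported only in words, as not active, so no step from compound 2 to compound 3 can be read. The compounds shown leave open how far cyclopentylcarbamoyl in place of fluoro shifts growth inhibition, and nothing given here bears on this result.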